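The source may hold more compounds than are shown below. What is called first, only, known or untested is meant among the compounds shown, and "the series" means these compounds.

In an ADME assay on A549 cells (Homo sapiens) for cytotoxicity, read by resazurin assay, with a stated time of 48 h (on this read-out higher numbers stand for lower toxicity in this test and lower numbers for higher toxicity in this test), three compounds have been measured:
- compound 1 `CCCNc1ccc(NC(=O)c2cc(Cl)ccc2O)c(Cl)c1`: 22500 nM
- compound 2 `CCCCCCC(C)Nc1ccc(NC(=O)c2cc(Cl)ccc2O)c(Cl)c1`: 23500 nM
- compound 3 `CC(C)(CCO)Nc1ccc(NC(=O)c2cc(Cl)ccc2O)c(Cl)c1`: 170000 nM

Compound 3 has the highest number of the three. Compound 4 `CC(CCO)Nc1ccc(NC(=O)c2cc(Cl)ccc2O)c(Cl)c1` differs from it by hydrogen in place of methyl on a saturated chain carbon bound to a nitrogen on an aromatic ring and two saturated chain carbons.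

Going by the values given here, no measured step isolates this change. The closest evidence is a 7.6-fold higher number from compound 1 to compound 3 (0.88 log units; beyond the scatter) and a 7.2-fold higher number from compound 2 to compound 3 (0.86 log units; beyond the scatter), both modest and beyond the scatter, while a 1.0-fold higher number from compound 1 to compound 2 (0.02 log units; within the scatter) lies within it. Compound 4 keeps the hydroxy group of the chain, so only a small drop is expected, possibly within the scatter. The expected change is a 1.4-fold lower number from compound 3 to compound 4 (0.15 log units; within the scatter). For compound 4 the estimate is 120000 nM, with an expected range of 50000 nM to 250000 nM.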

Compound 4, half-maximal cytotoxic concentration: 200000 nM
Estimate against measurement, compound 4: 1.7-fold (0.22 log units) below; the range from low to high includes it.
By their numbers in this assay, from the lowest: compounds 1 and 2 (each within the scatter of the next); then compounds 3 and 4 (each within the scatter of the next).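

In this assay, hydrogen in place of methyl on the saturated chain carbon bound to the nitrogen gives a 1.2-fold higher number from compound 3 to compound 4 (0.07 log units; within the scatter), so the second methyl of the 3-hydroxy-1,1-dimethylpropyl group makes no readable difference here. The 3-hydroxy-1-methylpropyl compound stays clear of the other two, with an 8.5-fold higher number from compound 2 to compound 4 (0.93 log units; beyond the scatter) and an 8.9-fold higher number from compound 1 to compound 4 (0.95 log units; beyond the scatter). The latter two steps show that the gap does not depend on that methyl. Nothing at hand explains this result. The compounds shown leave open whether a methoxy group, an amine or a carboxylic acid in place of the hydroxy group would give a similar number.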